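The source may report more compounds than this note shows. Statements on the series, on what has been measured and on what is new or still open speak of the compounds shown alone.

Measured so far:
- compound 1 `O=c1c2cnn(-c3ccc(F)cc3)c2ncn1CC1(O)CCN(Cc2ccncc2)CC1`: "not determined" (no result reported)
- compound 2 `O=c1c2cnn(-c3ccc(F)cc3)c2ncn1CC1(O)CCN(Cc2ccccc2F)CC1`: 9800 nM

Among the measured compounds shown here, in an assay on Sf21 cells for inhibition of ubiquitin carboxyl-terminal hydrolase 7 (Homo sapiens), read by spectrophotometry, with stated times of 30 min and 2 h (a higher number here means a weaker inhibitor, a lower number a stronger inhibitor), compound 2 gives 9800 nM, the only number in the set; compound 1 gives "not determined" (no result reported), so compound 2 cannot be placed against anything else and is simply a weak inhibitor on its own. Compound 3 `O=c1c2cnn(-c3ccc(F)cc3)c2ncn1CC1(O)CCN(Cc2ccc(Br)cc2Cl)CC1` differs from compound 2 by 4-bromo-2-chlorophenyl in place of 2-fluorophenyl on a saturated chain carbon bound to an amine nitrogen in a ring. For the measured compounds named here, no measured pair brackets such a change, so the expected step is small and of uncertain direction, likely not beyond the scatter: the step from compound 2 to compound 3 is estimated at a 1.4-fold lower number from compound 2 to compound 3 (0.15 log units; within the scatter). Compound 3 is therefore expected near 7000 nM, in the range 2500 nM to 20000 nM.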

Compound 3, half-maximal inhibitory concentration: 1900 nM
For compound 3 the middle estimate is 3.7-fold (0.57 log units) above the measured one, outside the stated range (below it).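

In this assay the group on the saturated chain carbon bound to the ring amine nitrogen clearly matters, with 4-bromo-2-chlorophenyl in place of 2-fluorophenyl giving a 5.2-fold lower number from compound 2 to compound 3 (0.71 log units; beyond the scatter) at this position. This single step cannot be divided among the halogens that differ. No available measurement accounts for the gain.

As far as these compounds go, it remains open whether the bromine or the chlorine alone carries the gain. From the compounds shown here alone, the response to a non-halogen group on this phenyl ring, such as methoxy or a carboxylic acid, also remains unknown.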